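The source may hold more compounds than are shown below. What is called first, only, known or untested is meant among the compounds shown, and "the series" means these compounds.

In an assay on isolated protein for inhibition of tyrosine-protein kinase receptor TYRO3 (Homo sapiens), read by LC-MS, with stated times of 30 min and 180 min (on this read-out higher numbers stand for weaker inhibition and lower numbers for stronger inhibition), compound 1, `CCn1c(-c2nnc(N(C)Cc3ccc4nccn4c3)o2)nc2ccccc21`, gives 39800 nM. Compound 2, `CN(Cc1ccc2nccn2c1)c1nnc(-c2ccc(-c3ccccc3Cl)nc2)o1`, gives 20000 nM in this assay. Compound 3, `CNC(=O)c1sc(N2CC3CC2(CNC(=O)c2c[nH]c4ncc(C(F)(F)F)cc24)C3)nc1C(F)(F)F`, is reported in this assay only as a limit, > 100000 nM, and sits at the limit of > 100000 nM in this assay, at which 1 of the 3 values shown sits, so no number is known for it. Compound 4, `CNC(=O)c1sc(N2CC3CC2(CNC(=O)c2c[nH]c4ncc(C)cc24)C3)nc1C(F)(F)F`, differs from compound 3 by methyl in place of trifluoromethyl on an aromatic carbon. No measured step of this kind stands among these compounds. Compound 3 gives no more than a limit, and compound 4 is expected to behave much the same, with the expected step of a number no higher from compound 3 to compound 4 (the limit leaves the size open) not beyond the scatter. The estimate for compound 4 in this assay is 100000 nM, with a range from 30000 nM to 300000 nM.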

Compound 4, half-maximal inhibitory concentration: 1000 nM
Compound 4: middle estimate off by 100-fold (2.00 log units), on the high side; measured number below the stated range.
By their numbers in this assay, from the lowest: compound 4; then compounds 2 and 1 (each within the scatter of the next). At a limit, above all of these: compound 3.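

In this assay, methyl in place of trifluoromethyl on this aromatic carbon gives an at least 100-fold lower number from compound 3 to compound 4 (2.00 log units; beyond the scatter). For the compounds shown here, this shows that the group at this position can decide the read-out on the shared core, which the earlier compounds could not show, as no step stood among them. The value of compound 3 is a limit and not a number, so the step has a lower bound only: the limit of > 100000 nM in this assay, at which 1 of the 4 values shown sits.

The compounds shown leave open how a hydrogen, a chlorine or an ethyl group at this carbon would read. As far as these compounds go, whether this change would have the same effect on another core also stays open.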